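Replacing one substituted phenyl group in compound 2

This account rests on a few compounds, and the source may have more. Where it says the series, first, only, none or still open, it means among the compounds named here.

In a functional assay on DU-145 cells (Homo sapiens) for inhibition, read by trypan blue exclusion, with a stated time of 96 h (a higher number here means a weaker inhibitor of growth, a lower number a stronger inhibitor of growth), compound 1 `O=C(O)c1ccc(C(=O)/C(=C\c2ccc(O)c([N+](=O)[O-])c2)SCc2ccc(Br)cc2)cc1` gives 50000 nM, compound 2 `O=C(/C(=C\c1ccc(O)c([N+](=O)[O-])c1)SCc1ccc(Br)cc1)c1ccc(Br)cc1` gives 10000 nM, and compound 3 `N#Cc1ccc(C(=O)/C(=C\c2ccc(O)c([N+](=O)[O-])c2)SCc2ccc(Br)cc2)cc1` gives 10000 nM. Compound 2 therefore stands level with compound 3, and together they hold the lowest number of the three.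

The next molecule, compound 4 `O=C(/C(=C\c1cc(Cl)c(O)c(Cl)c1)SCc1ccc(Br)cc1)c1ccc(Br)cc1`, has not been measured yet. It differs from compound 2 by having 3,5-dichloro-4-hydroxyphenyl in place of 4-hydroxy-3-nitrophenyl on a double-bonded chain carbon bound to a double-bonded chain carbon.

Three measured steps offer some guidance, though only indirectly. Bromo in place of carboxy gave a 5.0-fold lower number from compound 1 to compound 2 (0.70 log units; beyond the scatter), cyano in place of carboxy gave a 5.0-fold lower number from compound 1 to compound 3 (0.70 log units; beyond the scatter), and cyano in place of bromo gave no change at the digits printed from compound 2 to compound 3 (within the scatter). Each of these changes sits on an aromatic carbon, and all three compounds keep the 4-hydroxy-3-nitrophenyl group, so none of them tests the exchange made in compound 4. They give a sense of how large a step can be in this small set, but they point in no direction for this change.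

With no evidence for a direction, the expected step is no change at the digits printed from compound 2 to compound 4 (within the scatter). In this assay, compound 4 is estimated at 10000 nM, with an expected range from 3000 nM to 35000 nM.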

Compound 4, concentration for 50% growth inhibition: 10000 nM
The estimate for compound 4 equals the measured number at the digits printed; measured number inside the range.
By their numbers in this assay, from the lowest: compounds 2, 3 and 4 (each within the scatter of the next); then compound 1.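

In this assay, every earlier compound kept the 4-hydroxy-3-nitrophenyl group, so the steps among them said nothing about the group on this double-bonded chain carbon. Here that group itself is exchanged, and 3,5-dichloro-4-hydroxyphenyl in place of 4-hydroxy-3-nitrophenyl gives no change at the digits printed from compound 2 to compound 4 (within the scatter) for this pair. The nitro group can therefore leave this ring and two chloro groups can enter, with the hydroxy group kept, without the number moving beyond the scatter, although the entering group has fewer heavy atoms and fewer hydrogen-bond acceptors; nothing measured here bears on why the two groups read alike.

Both groups in this pair carry a hydroxy group, so the compounds shown leave open what happens at this position when a methoxy group or an amine stands in its place, or when the ring has no such substituent at all. Within the data shown here, the exchange has also been seen only with the bromophenyl ketone of compound 2, so whether it reads the same with the nitrile of compound 3 or the carboxylic acid of compound 1 remains open.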